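The source may report more compounds than this note shows. Statements on the series, on what has been measured and on what is new or still open speak of the compounds shown alone.

In a physicochemical assay for permeability, using PAMPA, with a stated time of 4 h, at pH 7.4, tested at 50 uM (a higher number here means that the compound crosses the layer faster, a lower number that the compound crosses the layer more slowly), compound 1 `O=C(O)CCCc1cn(CC(=O)O)c2c(/C=C/c3ccc(OCCCCc4c(F)ccc(F)c4F)cc3)cccc12` gives < 0.05 10^-6 cm/s, which is a limit of the assay rather than a number. Two further compounds were measured in the same way: compound 2 `Cc1c(Cl)cccc1CCCCOc1ccc(C#Cc2cccc3c(CCCC(=O)O)c(C)n(CCC(=O)O)c23)cc1` gives 3 10^-6 cm/s, and compound 3 `Cc1c(Cl)cccc1CCCCOc1ccc(C#Cc2cccc3c(CCCC(=O)O)c(C)n(CCCCC(=O)O)c23)cc1` gives 5 10^-6 cm/s. The step of a 1.7-fold higher number from compound 2 to compound 3 (0.22 log units; within the scatter) concerns a different part of the molecule and so says little about the change considered here. Compound 4 `O=C(O)CCCc1cn(CC(=O)O)c2c(/C=C/c3ccc(OCCCCOc4ccccc4)cc3)cccc12` differs from compound 1 by phenoxy in place of 2,3,6-trifluorophenyl on a saturated chain carbon, four bonds along the chain from an oxygen on an aromatic ring. Among the measured compounds shown here, no measured step matches this change, and compound 1 sits at the limit of < 0.05 10^-6 cm/s in this assay, at which 1 of the 3 values shown sits. Compound 4 is therefore expected to remain near that limit, with an estimated a number no lower from compound 1 to compound 4 (the limit leaves the size open) and an expected value of 0.05 10^-6 cm/s, between 0.02 10^-6 cm/s and 0.2 10^-6 cm/s.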

Compound 4, apparent permeability: < 0.05 10^-6 cm/s
Compound 4: no number, only a limit; the forecaster's own chance of this, stated with the estimate: 70%; the middle value sits exactly at the limit.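

Compound 1 and compound 4 each give only a limit, not a number, so no step can be read between them: the limit of < 0.05 10^-6 cm/s in this assay, at which 2 of the 4 values shown sit.

As far as these compounds go, whether phenoxy in place of 2,3,6-trifluorophenyl changes the read-out at all, and by how much, stays open.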